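Relocating a trifluoromethyl group on a phenyl ring

The compounds below may be only part of what the source reports. "The series", "measured", "known", "first", "only" and "open" are said of these compounds alone.

In a functional assay on T47D cells (Homo sapiens) for inhibition (a lower number here means a stronger inhibitor, a higher number a weaker inhibitor), compound 1 `Oc1ccccc1-c1cc(-c2ccc(F)cc2)cc(-c2ccccc2O)n1` gives > 50000 nM, which is a limit of the assay and not a number. For the measured compounds named here, compound 2 `Oc1ccccc1-c1cc(-c2ccccc2C(F)(F)F)cc(-c2ccccc2O)n1` gives 22500 nM, the only actual number so far, and it can be compared only with the result for compound 1.

Compound 3 `Oc1ccccc1-c1cc(-c2ccc(C(F)(F)F)cc2)cc(-c2ccccc2O)n1` has the same atoms as compound 2, joined differently: 4-(trifluoromethyl)phenyl in place of 2-(trifluoromethyl)phenyl on an aromatic carbon. A 4-(trifluoromethyl)phenyl takes the place of the 2-(trifluoromethyl)phenyl on the aromatic carbon opposite the ring nitrogen.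

Going by the values given here, only one measured step bears on this change: an at least 2.2-fold lower number from compound 1 to compound 2 (0.34 log units; beyond the scatter). That step changed both the kind of group and its place, so it cannot separate the two. Compound 3 resembles compound 1 in one respect, a 4-substituted phenyl, and compound 2 in another, the trifluoromethyl group. Among the compounds with values here, with so modest a step as the only guide, no change beyond the scatter is expected in this assay, though a drift towards weaker inhibition would not surprise. The expected step is a 1.3-fold higher number from compound 2 to compound 3 (0.12 log units; within the scatter). For compound 3 the estimated value is 30000 nM, with an expected range of 10000 nM to 50000 nM.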

Compound 3, half-maximal inhibitory concentration: > 50000 nM
Compound 3: a limit, no number; the forecaster's own chance of this, stated with the estimate: 35%; at least 1.6-fold (0.22 log units) between middle value and limit.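

Moving the trifluoromethyl group around its phenyl ring matters in this assay, with an at least 2.2-fold higher number from compound 2 to compound 3 (0.34 log units; beyond the scatter). The earlier step from compound 1 to compound 2 changed both the kind of group and its place, whereas this step keeps the same atoms and changes only how they are joined, so the place on the phenyl ring counts by itself. Among these two compounds, the 2-(trifluoromethyl)phenyl of compound 2 gives the stronger inhibition, although the value of compound 3 is a limit of the assay and not a number, so the full size of this step stays unknown.

As far as these compounds go, the step from compound 1 to compound 3, which would compare fluoro and trifluoromethyl on a 4-substituted phenyl, cannot be read because both results are limits: the limit of > 50000 nM in this assay, at which 2 of the 3 values shown sit. It remains open whether the stronger result of compound 2 belongs to the trifluoromethyl group itself, or whether a methoxy group or a chlorine atom in the same place on the phenyl ring would give a similar number.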